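The source may report more compounds than this note shows. Statements on the series, on what has been measured and on what is new or still open speak of the compounds shown alone.

Working notes on the series. Compound 1 `Cc1cc(NC(=O)Nc2ccc(C(=O)O)cc2)c2ccccc2n1` was run in an ADME assay on HepG2 cells (Homo sapiens) for cytotoxicity, with a stated time of 72 h; a higher number here means that more compound is needed for the effect, a lower number that less compound is needed; there compound 1 returns only a limit of the assay, > 25000 nM, so its place on the scale is fixed no further than that bound. Compound 2 `Cc1cc(NC(=O)Nc2ccccc2C(F)(F)F)c2ccccc2n1` likewise stops at the limit > 25000 nM in this assay. Compound 3 `CSc1ccccc1NC(=O)Nc1cc(C)nc2ccccc12` also ends at the limit > 25000 nM in this assay. Among the measured compounds shown here, the single step between measured compounds that differ in one place, a step that the two limits leave unreadable from compound 2 to compound 3, is therefore not readable in size or direction, since (the limit of > 25000 nM in this assay, at which 3 of the 3 values shown sit).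

The unmeasured compound 4 `CC(=O)c1ccc(NC(=O)Nc2cc(C)nc3ccccc23)cc1` differs from compound 1 in one place: methyl in place of hydroxy on a carbonyl carbon. For the measured compounds named here, no measured step touches this position, and the only measured step at all is itself unreadable, so nothing sized bears on the change; the three values share only that each sits at the limit.

Compound 4 is expected to stay at the limit because compound 1 itself shows only > 25000 nM. The step that the limit leaves unreadable from compound 1 to compound 4 is accordingly expected to be none beyond the scatter. The estimate for compound 4 in this assay is 40000 nM, with a range from 15000 nM to 150000 nM, and it is expected to appear most likely as a limit rather than a number.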

Compound 4, half-maximal effective concentration: 19000 nM
Compound 4: the middle estimate sits 2.1-fold (0.32 log units) above what was measured; measured number inside the range.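

In this assay, among the compounds shown here, compound 4 gives 19000 nM, a number and not a limit, so this position yields the first value of the series with a fixed place on the scale. Acetyl in place of carboxy, a change on a carbonyl carbon whose other neighbour is an aromatic carbon, reads as an at least 1.3-fold lower number from compound 1 to compound 4 (0.11 log units; that floor lies within the scatter). For the compounds shown here, this is the first step that can be given any size, yet it is only a floor, and the real distance between the two compounds stays unfixed because compound 1 returns a limit: the limit of > 25000 nM in this assay, at which 3 of the 4 values shown sit.

Going by these compounds, whether a number of this kind is particular to acetyl or would also appear with another group on the same carbonyl carbon, such as a primary amide or a methyl ester, stays open. On these data alone, the actual values of compound 1, compound 2 and compound 3 also remain unknown, so no order among those three can be given, and the effect of the change on any other member of the series cannot be told from this single pair.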